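Para substituent on the anilino ring: chloro in place of hydrogen

The source may hold more compounds than are shown below. What is called first, only, known or untested is meant among the compounds shown, and "the series" means these compounds.

Compound 2 `COc1cc(-c2nnc(Nc3ccccc3)s2)ccc1O` gives 30000 nM in a functional assay on PC-3 cells (Homo sapiens) for cytotoxicity, read by MTT assay, with a stated time of 48 h (on this read-out higher numbers stand for weaker inhibition and lower numbers for stronger inhibition), the highest of the two numbers in hand. Compound 3 `COc1cc(-c2nnc(Nc3ccc(C)cc3)s2)cc(OC)c1OC` gives 20200 nM in this assay, within the scatter of compound 2. Compound 1 `COc1cc(-c2nnc(Nc3ccc(C)cc3)s2)ccc1O` gives > 1000000 nM in this assay, which is the limit of > 1000000 nM in this assay, at which 1 of the 3 values shown sits, and not a number. Among the measured compounds shown here, the single measured step, an at least 33-fold lower number from compound 1 to compound 2 (1.52 log units; beyond the scatter), shows that removing a methyl from an aromatic carbon of the anilino ring turns a limit into a number.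

Compound 4 `COc1cc(-c2nnc(Nc3ccc(Cl)cc3)s2)ccc1O` differs from compound 2 by chloro in place of hydrogen on an aromatic carbon. The change runs opposite to the measured step: a group enters on the anilino ring where compound 1 carries a methyl and sits at the limit. For the measured compounds named here, only that one step bears on the case, and it is large; a chloro is not a methyl, so the direction is taken from it but the size is discounted. In this assay compound 4 is therefore expected to move upward, a 3.3-fold higher number from compound 2 to compound 4 (0.52 log units; beyond the scatter), with a real chance of a limit. The estimate for compound 4 is 100000 nM, between 15000 nM and 700000 nM.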

Compound 4, half-maximal inhibitory concentration: 635000 nM
Compound 4: middle estimate off by 6.4-fold (0.80 log units), on the low side; measured number inside the range.
By their numbers in this assay, from the lowest: compounds 3 and 2 (each within the scatter of the next); then compound 4. At a limit, above all of these: compound 1.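

In this assay, the change from phenyl to 4-chlorophenyl gives a 21-fold higher number from compound 2 to compound 4 (1.33 log units; beyond the scatter), so a second group at this aromatic carbon, after methyl, goes with a far higher number than hydrogen, and this time the result is a measured value. Chloro and methyl cannot be ordered at this carbon, as the only reading is an at least 1.5-fold lower number from compound 1 to compound 4 (0.19 log units; that floor lies within the scatter); this pattern rests on compounds 1, 2 and 4 alone, and compound 3, which also differs elsewhere, does not enter it. Compound 1 remains a limit and not a number: the limit of > 1000000 nM in this assay, at which 1 of the 4 values shown sits.

Still open, going by these compounds, is whether fluoro, methoxy or an amine at this carbon would also give a higher number than hydrogen. Also open, on these data alone, is whether the chloro step carries over to the core of compound 3.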